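A few compounds are considered here, and "the series" means these few. Any claim that something is new, unique, unknown or untested is made for them only; others in the source may bear on it.

Of the compounds shown here, three have been measured in a functional assay on CHO-K1 cells for antagonist activity at C-X-C chemokine receptor type 3 (Homo sapiens), read by FLIPR, with a stated time of 10 min; a higher number here means a weaker inhibitor, a lower number a stronger inhibitor. Compound 1 `O=C(Cn1cnc2cccnc21)N1CCN(c2scnc2-c2nc3ccccc3[nH]2)CC1` gives 30 nM in this assay, and compound 2 `C[C@@H]1CN(c2sc(CN(C)C)nc2-c2nc3ccccc3[nH]2)CCN1C(=O)Cn1cnc2cccnc21` gives 50 nM. Compound 3 `CCOc1ncc(-c2nc(C(F)(F)F)sc2N2CCN(C(=O)Cn3ccc4cccnc43)[C@H](C)C2)cn1` gives 3.8 nM in this assay, which is the lowest of the three numbers, and therefore the strongest inhibition seen so far; the gap to compound 1 and the gap to compound 2 both lie beyond the usual scatter of repeated measurements, so compound 3 stands apart from the other two rather than merely sitting at the edge of noise.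

Compound 4 `CCOc1ncc(-c2nc(C(F)(F)F)sc2N2CCN(C(=O)Cn3c(=O)oc4ccccc43)[C@H](C)C2)cn1` is the next compound to be measured. It keeps the shared core of compound 3 and differs from it in one place: a group of 10 heavy atoms (7 carbon, 1 nitrogen, 2 oxygen; one five-membered aromatic ring with 2 hetero atoms, one six-membered aromatic ring of carbon only) in place of a group of 9 heavy atoms (7 carbon, 2 nitrogen; one five-membered aromatic ring with 1 hetero atom, one six-membered aromatic ring with 1 hetero atom), on a saturated chain carbon bound to a carbonyl carbon. Among the measured compounds shown here, no pair among the measured compounds differs in exactly this way, so there is no measured step to lean on, and the expectation rests only on the fact that this group is exchanged while everything else in compound 3 is kept.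

Since compound 3 gives 3.8 nM in this assay and the change swaps one two-ring group for another of similar size at the same place, compound 4 is expected to stay in the same region, with a small step toward weaker inhibition of a 2.4-fold higher number from compound 3 to compound 4 (0.37 log units; beyond the scatter) that may or may not exceed the scatter. The estimate for compound 4 in this assay is 9 nM, expected to fall between 3 nM and 30 nM.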

Compound 4, half-maximal inhibitory concentration: 3.3 nM
Compound 4: middle estimate off by 2.7-fold (0.44 log units), on the high side; low and high end bracket the measured number.
By their numbers in this assay, from the lowest: compounds 4 and 3 (each within the scatter of the next); then compounds 1 and 2 (each within the scatter of the next).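

In this assay, exchanging the two-ring group on a saturated chain carbon bound to a carbonyl carbon gives a 1.2-fold lower number from compound 3 to compound 4 (0.06 log units; within the scatter), so compound 3 and compound 4 cannot be told apart. Among the compounds shown here, this is the first direct reading at this position, as the earlier compounds differ from one another in more than one place. It shows that, with the rest of compound 3 kept, a group with a six-membered aromatic ring of carbon only and a double bond outside the aromatic rings can stand in for one with a six-membered aromatic ring with 1 hetero atom, with no measurable loss of inhibition. Nothing measured here explains why these two groups give such similar results.

This single pair leaves open how much of the two-ring group the position needs: a single phenyl ring or a short alkyl chain at the same place might or might not hold inhibition at this level. From the compounds shown here alone, it also remains open whether the same exchange would be tolerated on a different core, such as that of compound 1, where the rest of the molecule differs from compound 3 and compound 4.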